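Opening a Five-Membered Sulfur Ring: Expected Growth Inhibition

The source may hold more compounds than are shown below. What is called first, only, known or untested is meant among the compounds shown, and "the series" means these compounds.

Measured compounds:
compound 1, `O=C(CCCCC1CCSS1)Nc1ccccn1`: "not active" (no number reported)
compound 2, `O=C(CCCCC1CCSS1)Nc1ccc(Br)cn1`: 35.1%

In a functional assay on KB cells (Homo sapiens) for inhibition, read by MTT assay, with a stated time of 24 h, tested at 10 ug/mL (on this read-out lower numbers stand for less inhibition of growth and higher numbers for more inhibition of growth at the one concentration tested), compound 2 gives 35.1%. Among the compounds with values here, that is the only number in this small set; compound 1 is recorded in this assay as "not active" (no number reported), with no figure attached. Within the data shown here, compound 2 therefore stands alone as the single compound with a measured degree of growth inhibition, and nothing here shows how far any structural change moves that read-out.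

Compound 3, `O=C(CCCCC(S)CCS)Nc1ccc(Br)cn1`, has not yet been measured. It differs from compound 2 in one place: a group of 5 heavy atoms (3 carbon, 2 sulfur; no ring) in place of a group of 5 heavy atoms (3 carbon, 2 sulfur; one five-membered non-aromatic ring with 2 hetero atoms), on a saturated chain carbon, four bonds along the chain from a carbonyl carbon. Among the measured compounds shown here, no step between measured compounds exists to calibrate this change, so the expectation rests on compound 2 alone. A step of modest size is expected, leaning slightly downward but likely within the usual scatter. Compound 3 is expected to give 30% in this assay, within a range from 10% to 50%. This estimate implies a step of a number 5.1 percentage points lower from compound 2 to compound 3 (within the scatter).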

Compound 3, percent growth inhibition at one concentration: 34.1%
Compound 3: middle estimate off by 4.1 percentage points, on the low side; low and high end bracket the measured number.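

Within the data shown here, replacing the five-membered sulfur ring with the open 1,3-disulfanylpropyl group, on this saturated chain carbon, gives the first readable step at this position: in this assay, the result is a number 1 percentage points lower from compound 2 to compound 3 (within the scatter). The two compounds cannot be told apart on this read-out, so in this one pair the closed ring is not needed to keep the level of growth inhibition, even though the open group carries 2 hydrogen-bond donors and the ring carries 0. No measurement shown here explains why the two compounds read alike.

On these data alone, whether the sulfur atoms themselves matter remains open, and a plain propyl group or a carboxylic acid at this place would test that. Also open, as far as these compounds go, is whether the ring and the open group would still match with a chlorine in place of the bromine.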